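Cytotoxicity series: aryl-substituted core acids on THP-1 cells

A few compounds are considered here, and "the series" means these few. Any claim that something is new, unique, unknown or untested is made for them only; others in the source may bear on it.

Measured so far:
- compound 1 `COc1ccc(/C=C2\CC[C@H]3C(C)(C)CCC[C@]3(C)[C@H]2CCC(C)CC(=O)O)cc1`: > 200000 nM
- compound 2 `Cc1ccc(/C=C2\CC[C@H]3C(C)(C)CCC[C@]3(C)[C@H]2CCC(C)CC(=O)O)cc1`: > 200000 nM

In a functional assay on THP-1 cells (Homo sapiens) for cytotoxicity, read by MTT assay, with a stated time of 24 h (a lower number here means a stronger inhibitor, a higher number a weaker inhibitor), compound 1 gives > 200000 nM, which is a limit of the assay and not a number. In this assay compound 2 gives > 200000 nM, likewise a limit rather than a number. Among the measured compounds shown here, the only step between measured compounds, a step that the two limits leave unreadable from compound 1 to compound 2, cannot be read in size, since both ends sit at the limit of > 200000 nM in this assay, at which 2 of the 2 values shown sit. Compound 2 therefore stands at the limit, with no measured number to place it against compound 1.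

Compound 3 `CC(CC[C@H]1/C(=C/c2ccc([N+](=O)[O-])cc2)CC[C@H]2C(C)(C)CCC[C@]12C)CC(=O)O` differs from compound 2 by nitro in place of methyl on an aromatic carbon, read one bond further out as 4-methylphenyl to 4-nitrophenyl. For the measured compounds named here, no measured step involves a nitro group, and the single measured step gives no readable size. There is thus no basis to expect a step beyond the scatter in either direction in this assay. Compound 3 is expected to remain at or beyond the limit, with an estimated step that the limit leaves unreadable from compound 2 to compound 3 and an estimated value of 300000 nM, range 100000 nM to 1000000 nM.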

Compound 3, half-maximal inhibitory concentration: 180000 nM
Beside the measured number, compound 3's estimate is 1.7-fold (0.22 log units) above it; the measured number falls inside the stated range.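

In this assay, among the compounds shown here, compound 3 gives 180000 nM, the first true number for a group on this aromatic carbon, para to a large group. Compound 1 and compound 2 each stand at a limit of the assay and not at a number: the limit of > 200000 nM in this assay, at which 2 of the 3 values shown sit. Against those limits, the change to nitro reads as an at least 1.1-fold lower number from compound 2 to compound 3 (0.04 log units; that floor lies within the scatter), and the change from methoxy reads as an at least 1.1-fold lower number from compound 1 to compound 3 (0.04 log units; that floor lies within the scatter), so this position now has a measured value but no step shown to lie beyond the scatter.

On these data alone, the step between compound 1 and compound 2 cannot be read, and whether the true values of those two compounds lie close to compound 3 or far from it remains open, since the two steps to compound 3 give only floors. Also open, as far as these compounds go, is what an amine or a nitrile on the same aromatic carbon would give in this assay, and whether any group at this position can move the number clearly beyond the scatter.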